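Cytotoxicity on canine kidney cells: nitrile replacing thioether

The source may report more compounds than this note shows. Statements on the series, on what has been measured and on what is new or still open speak of the compounds shown alone.

Three tertiary amines built on a shared core carry a benzyl group that differs only in its substituent. Compound 1 `CCOc1ccc(CN(Cc2ccc(C(C)(C)C)cc2)Cc2cc3cc(C)ccc3[nH]c2=O)cc1` has ethoxy there, compound 2 `Cc1ccc2[nH]c(=O)c(CN(Cc3ccc(OCCO)cc3)Cc3ccc(C(C)(C)C)cc3)cc2c1` has 2-hydroxyethoxy and compound 3 `CSc1ccc(CN(Cc2ccc(C(C)(C)C)cc2)Cc2cc3cc(C)ccc3[nH]c2=O)cc1` has methylsulfanyl. In a toxicity assay on MDCK cells (Canis lupus familiaris) for cytotoxicity, read by crystal violet staining, with a stated time of 48 h (a higher number here means that more compound is tolerated, a lower number that less compound is tolerated), compound 1 gives > 10000 nM, which is a limit of the assay rather than a number. In this assay compound 2 gives > 5000 nM, again a limit. In this assay compound 3 gives > 5000 nM, also a limit. Compound 3 therefore stands where all three values stand: at a limit, with no measured number anywhere in the set, as the two lines the limit of > 10000 nM in this assay, at which 1 of the 3 values shown sits, and the limit of > 5000 nM in this assay, at which 2 of the 3 values shown sit, record. The steps a step that the two limits leave unreadable from compound 1 to compound 2, a step that the two limits leave unreadable from compound 1 to compound 3 and a step that the two limits leave unreadable from compound 2 to compound 3 remain unreadable for that reason.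

Compound 4 `Cc1ccc2[nH]c(=O)c(CN(Cc3ccc(C#N)cc3)Cc3ccc(C(C)(C)C)cc3)cc2c1` is the next member: cyano in place of methylsulfanyl on an aromatic carbon. Going by the values given here, no measured step in this assay can be read, so no direction or size can be drawn from the set; the only guidance is that every compound so far was tolerated up to its limit. The step that the limit leaves unreadable from compound 3 to compound 4 is therefore expected to stay within the scatter, and compound 4 is expected to give about 8000 nM, within 3000 nM to 30000 nM, most likely reported again as a limit.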

Compound 4, half-maximal cytotoxic concentration: > 5000 nM
Compound 4: only a limit was reported; the forecaster's own chance of this, stated with the estimate: 80%; the middle value does not contradict the limit.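

In this assay compound 4 gives > 5000 nM, which is a limit of the assay. Its steps to compound 1, compound 2 and compound 3 cannot be read, since all four values are limits: the limit of > 5000 nM in this assay, at which 3 of the 4 values shown sit.

Still open, as far as these compounds go, is whether the cytotoxic concentrations of these four compounds differ at all, since none has a measured number.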